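Swapping the aminophenyl of compound 1 for a dichlorophenyl

This account rests on a few compounds, and the source may have more. Where it says the series, first, only, none or still open, it means among the compounds named here.

Measured compounds:
compound 1, `COc1cc(-c2cc(/C=C/C(=O)c3ccc(N)cc3)[nH]n2)cc(OC)c1OC`, 43%
compound 2, `COc1ccc(-c2cc(/C=C/C(=O)c3ccc(OC)c(OC)c3)[nH]n2)cc1`, 56%

In a functional assay on K562 cells (Homo sapiens) for cytotoxicity, read by sulforhodamine B assay, with a stated time of 48 h, tested at 1 uM (on this read-out higher numbers stand for a weaker effect at the one concentration tested and lower numbers for a stronger effect), compound 1 gives the lowest of the two numbers, and compound 2 lies a number higher than compound 1 by more than the scatter. Compound 3, `COc1cc(-c2cc(/C=C/C(=O)c3ccc(Cl)c(Cl)c3)[nH]n2)cc(OC)c1OC`, differs from compound 1 by 3,4-dichlorophenyl in place of 4-aminophenyl on a carbonyl carbon. Among the measured compounds shown here, no step of this kind has been measured, so the expectation rests on compound 1 alone; a small rise, hardly beyond the scatter, is expected, a number 7 percentage points higher from compound 1 to compound 3 (within the scatter). For compound 3 the estimated value is 50%, likely between 30% and 72%.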

Compound 3, a percentage reported as activity, at one concentration (the size of the read-out at that concentration, not a potency): 101%
Compound 3: the middle estimate sits 51 percentage points below what was measured; the measured number lies above the stated range.
By their numbers in this assay, from the lowest: compound 1; then compound 2; then compound 3.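

In this assay the group on the carbonyl carbon matters a great deal: there is a number 58 percentage points higher from compound 1 to compound 3 (beyond the scatter) when 3,4-dichlorophenyl stands in place of 4-aminophenyl, which means a far weaker effect at the one concentration tested. So, with the rest of compound 1 unchanged, one six-membered aromatic ring here cannot simply stand in for another. Nothing available explains this loss.

Still open, as far as these compounds go, is whether losing the amine or gaining the two chlorines drives the step. A plain phenyl or a 4-hydroxyphenyl on the same carbonyl carbon would help separate the two.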